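Methyl for Trifluoromethyl on the Shared Core

The compounds below may be only part of what the source reports. "The series", "measured", "known", "first", "only" and "open" are said of these compounds alone.

compound 1 `CN(C(=O)NC(=O)c1c(F)cccc1F)c1nc(C(F)(F)F)c(C(=O)N/N=C/c2cc(C(F)(F)F)cc(C(F)(F)F)c2)s1` — 5.28 ug/mL
compound 2 `CN(C(=O)NC(=O)c1ccc(F)c(F)c1)c1nc(C(F)(F)F)c(C(=O)N/N=C/c2cc(C(F)(F)F)cc(C(F)(F)F)c2)s1` — 3.51 ug/mL

Of the compounds shown here, two have been measured in a functional assay on BCG823 cells (Homo sapiens) for inhibition, read by MTT assay, with a stated time of 72 h; a higher number here means a weaker inhibitor, a lower number a stronger inhibitor. Compound 1 gives 5.28 ug/mL, the highest of the two numbers; its nearest neighbour is compound 2, and the step of a 1.5-fold lower number from compound 1 to compound 2 (0.18 log units; within the scatter) shows that the two stand within the scatter of each other. The change followed here leads from compound 1 to compound 3 `Cc1nc(N(C)C(=O)NC(=O)c2c(F)cccc2F)sc1C(=O)N/N=C/c1cc(C(F)(F)F)cc(C(F)(F)F)c1`, which has not yet been measured. The difference is methyl in place of trifluoromethyl on an aromatic carbon. Among the compounds with values here, no measured step touches this position: the only step measured so far, between compound 1 and compound 2, concerns the group on a carbonyl carbon, and it lay within the scatter. Nothing in the two measurements therefore points to a direction for the exchange of trifluoromethyl for methyl on the aromatic carbon of the shared core, so the expectation rests on compound 1 alone and carries a wide range. For compound 3 the expected step is a 1.1-fold higher number from compound 1 to compound 3 (0.06 log units; within the scatter). The estimate for compound 3 in this assay is 6 ug/mL, with a range from 2.5 ug/mL to 15 ug/mL.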

Compound 3, half-maximal inhibitory concentration: 14.1 ug/mL
Estimate against measurement, compound 3: 2.4-fold (0.37 log units) below, within the range that was stated.
By their numbers in this assay, from the lowest: compounds 2 and 1 (each within the scatter of the next); then compound 3.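

Within the data shown here, until now no measured step had touched this position on the shared core. In this assay, among these compounds, the exchange gives a 2.7-fold higher number from compound 1 to compound 3 (0.43 log units; beyond the scatter) and so becomes the first step here to lie beyond the scatter, though a modest one. Among the compounds shown here, the number at this aromatic carbon, next to the ring nitrogen, therefore responds to methyl in place of trifluoromethyl, whereas the only earlier step, on a carbonyl carbon, stayed within the scatter. No evidence at hand bears on what lies behind this rise.

One exchange cannot show whether the rise is particular to methyl or would follow from any group replacing trifluoromethyl, so the compounds shown leave open how a hydrogen, a chlorine atom, an ethyl group or an amine would stand at this aromatic carbon. They also leave open whether the same exchange on compound 2, with its 3,4-difluorophenyl group on the carbonyl carbon, would give a step of similar size.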